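The compounds below may be only part of what the source reports. "The series", "measured", "known", "first", "only" and "open" are said of these compounds alone.

Compound 1, `CCCc1nc(C)c2c(C)nnc(SC)n12`: in a functional assay for inhibition, with Homo sapiens as the target (a higher number here means a weaker inhibitor, a lower number a stronger inhibitor), compound 1 reaches only > 48000 nM, a limit of the assay.
Compound 2, `CCCc1ncc2c(C)nnc(S)n12`: in this assay compound 2 reaches only > 48000 nM, again a limit.
Compound 3, `CCCc1nc(C)c2c(C)nnc(S)n12`: in this assay compound 3 gives 45000 nM.

Compound 2 thus stands at a limit, not a number, and so does compound 1 (the limit of > 48000 nM in this assay, at which 2 of the 3 values shown sit); only compound 3 gives a value at all, and that value barely clears the limit. Compound 4, `CCCc1ncc2c(C)nnc(SC)n12`, carries methyl in place of hydrogen on a sulfur. The measured step that bears on this change runs the other way: an at least 1.0-fold lower number from compound 1 to compound 3 (0.02 log units; that floor lies within the scatter), a step within the scatter. No change beyond the scatter is therefore expected in this assay, and compound 4 is expected to sit at 60000 nM, within 30000 nM to 150000 nM, most likely reported again as a limit, which means an estimated step that the limit leaves unreadable from compound 2 to compound 4.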

Compound 4, half-maximal inhibitory concentration: > 48000 nM
Compound 4: only a limit was reported; the forecaster's own chance of this, stated with the estimate: 70%; the middle value does not contradict the limit.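

Compound 4 ends at a limit of the assay, as do compound 1 and compound 2, so no step from either compound to compound 4 can be read: the limit of > 48000 nM in this assay, at which 3 of the 4 values shown sit.

As far as these compounds go, whether methyl in place of hydrogen on the sulfur changes anything in this assay stays open.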